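Replacing a branched acid by an amide chain

The source may report more compounds than this note shows. Statements on the series, on what has been measured and on what is new or still open speak of the compounds shown alone.

Of the compounds shown here, three have been tested in a functional assay on CHO cells for agonist activity at Free fatty acid receptor 1 (Homo sapiens), read by a luciferase reporter; a higher number here means a larger maximal response, a lower number a smaller maximal response. Compound 1 `O=C(O)COc1ccc(NCc2cccc(Oc3ccccc3)c2)cc1` gives 84%, compound 3 `Cc1nc(-c2ccc(C(F)(F)F)cc2)sc1CNc1ccc(CC(C)C(=O)O)cc1` gives 100%, and compound 2 `CC(C)(Oc1ccc(NCc2cccc(Oc3ccccc3)c2)cc1)C(=O)O` gives 14%, the lowest of the three. Among the compounds with values here, the one step within this set, a number 70 percentage points lower from compound 1 to compound 2 (beyond the scatter), shows how strongly a branched acid group lowered the response. Compound 4 `NC(=O)CCc1ccc(NCc2cccc(Oc3ccccc3)c2)cc1` differs from compound 2 by 2-carbamoylethyl in place of 1-carboxy-1-methylethoxy on an aromatic carbon. Within the data shown here, no measured step swaps the acid for an amide, so the branching loss and the acid loss pull in opposite directions. Compound 4 is expected to recover part of the response, as in the estimated step of a number 36 percentage points higher from compound 2 to compound 4 (beyond the scatter). Compound 4 is estimated at 50%, between 15% and 90%.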

Compound 4, largest response reached (reported as percent of maximum), in percent of the reference or control that the assay uses: 68%
For compound 4 the middle estimate is 18 percentage points below the measured one; measured number inside the range.
By their numbers in this assay, from the lowest: compound 2; then compound 4; then compound 1; then compound 3.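

Putting 2-carbamoylethyl in place of 1-carboxy-1-methylethoxy gives a number 54 percentage points higher from compound 2 to compound 4 (beyond the scatter) in this assay, so among these compounds a large response at this position does not need a carboxylic acid. The amide chain does not fully match the unbranched acid, with a number 16 percentage points lower from compound 1 to compound 4 (beyond the scatter). No evidence at hand explains either step. Still open, on these data alone, is whether the response depends on the amide itself or on the chain that carries it. A nitrile on the same chain, or a longer chain ending in the amide, would help separate the two.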